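The source may hold more compounds than are shown below. What is called first, only, known or untested is meant among the compounds shown, and "the series" means these compounds.

Compound 2 `CCS(=O)(=O)Nc1cc(-c2ccc3ncnc(Nc4ccc(F)cc4F)c3c2)cnc1OC` is one of two closely related compounds built on the same core, the other being compound 1 `CCS(=O)(=O)Nc1cc(-c2ccc3ncnc(Nc4cccc(F)c4)c3c2)cnc1OC`. In a functional assay on BT-549 cells (Homo sapiens) for cytotoxicity, read by sulforhodamine B assay, with a stated time of 72 h (a lower number here means a stronger inhibitor, a higher number a weaker inhibitor), compound 2 gives 2480 nM, and compound 1 gives 2760 nM. Compound 2 thus has the lower of the two numbers, but the gap is small: the step of a 1.1-fold lower number from compound 1 to compound 2 (0.05 log units; within the scatter) is within the scatter, so the two readings cannot be told apart with confidence.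

The new compound, compound 3 `CCS(=O)(=O)Nc1cc(-c2ccc3ncnc(Nc4ccc(OC(F)(F)F)cc4)c3c2)cnc1OC`, differs from compound 2 in one place: 4-(trifluoromethoxy)phenyl in place of 2,4-difluorophenyl on a nitrogen on an aromatic ring. Within the data shown here, the only measured step that touches this position is the step from compound 1 to compound 2, in which one fluorinated phenyl group replaced another and the number hardly moved. Among the measured compounds shown here, that is the sole guide available, and it speaks for a small step.

On that basis compound 3 is expected to give a value close to compound 2 in this assay, an estimated 2500 nM within a range of 900 nM to 7000 nM. The expected step of a 1.0-fold higher number from compound 2 to compound 3 (0.00 log units; within the scatter) is therefore one that need not reach beyond the scatter.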

Compound 3, half-maximal inhibitory concentration: 8240 nM
Compound 3: the middle estimate sits 3.3-fold (0.52 log units) below what was measured; the whole stated range lies below it.
By their numbers in this assay, from the lowest: compounds 2 and 1 (each within the scatter of the next); then compound 3.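

The step from compound 1 to compound 2 suggested that this nitrogen substituent could change with little effect, but the new group shows that the position does respond to what sits there. In this assay, 4-(trifluoromethoxy)phenyl in place of 2,4-difluorophenyl gives a 3.3-fold higher number from compound 2 to compound 3 (0.52 log units; beyond the scatter), and in place of 3-fluorophenyl it gives a 3.0-fold higher number from compound 1 to compound 3 (0.48 log units; beyond the scatter), so both comparisons point towards a weaker compound by a modest amount that lies beyond the scatter. The entering group differs from the leaving groups in more than one way, with more heavy atoms and a hydrogen-bond acceptor, and nothing available shows which of these differences, if any, accounts for the higher number.

Only three groups at one position are shown, so it remains open whether the higher number belongs to the oxygen, the trifluoromethyl end or the overall size of the group; 4-methoxyphenyl and 4-(trifluoromethyl)phenyl would help to separate these. As far as these compounds go, it is also open whether a phenyl ring carrying an amine or a carboxylic acid would move the number in either direction, or whether any group here can bring it well below the level of compound 1 and compound 2.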